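Shortening the alkyl branch on a CRF receptor ligand

The source may hold more compounds than are shown below. What is called first, only, known or untested is meant among the compounds shown, and "the series" means these compounds.

Measured compounds:
- compound 1: `CCCC(C)n1c(CC)nc2c(-c3ccc(OC)nc3C)ccnc21` — 1.1 nM
- compound 2: `CCc1nc2c(-c3ccc(OC)nc3C)ccnc2n1C(C)C1CCC1` — 2.1 nM

Compound 1 and compound 2 share one core and differ only in the group on the saturated chain carbon bound to the aromatic nitrogen and a saturated chain carbon. In an assay for binding affinity to Corticotropin releasing factor receptor (Rattus norvegicus) (a lower number here means a stronger inhibitor, a higher number a weaker inhibitor), compound 1 gives 1.1 nM. In this assay compound 2 gives 2.1 nM; the step of a 1.9-fold higher number from compound 1 to compound 2 (0.28 log units; within the scatter) shows that swapping propyl for cyclobutyl at that position leaves the number within the scatter. Compound 2 thus has the higher of the two numbers measured, but it stands within the scatter of compound 1.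

Compound 3, `CCc1nc2c(-c3ccc(OC)nc3C)ccnc2n1C(C)CC`, carries the change (ethyl in place of cyclobutyl on a saturated chain carbon bound to an aromatic nitrogen and a saturated chain carbon). Among the measured compounds shown here, the only step that bears on this position, a 1.9-fold higher number from compound 1 to compound 2 (0.28 log units; within the scatter), was within the scatter, so a branch of different shape at this carbon has so far left the number about where it was. Because a 1.9-fold higher number from compound 1 to compound 2 (0.28 log units; within the scatter) is small, compound 3 is expected to move little, with at most a modest rise in the number, that is a 1.2-fold higher number from compound 2 to compound 3 (0.09 log units; within the scatter). Compound 3 is therefore estimated at 2.6 nM, with a range from 1 nM to 7 nM.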

Compound 3, inhibition constant: 9.2 nM
Estimate against measurement, compound 3: 3.5-fold (0.55 log units) below, and the stated range ends below it.
By their numbers in this assay, from the lowest: compounds 1 and 2 (each within the scatter of the next); then compound 3.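

In this assay, this branch turns out not to be indifferent to change: ethyl in place of cyclobutyl on the saturated chain carbon bound to an aromatic nitrogen and a saturated chain carbon gives a 4.4-fold higher number from compound 2 to compound 3 (0.64 log units; beyond the scatter), and hydrogen in place of methyl on the saturated chain carbon, three bonds along the chain from an aromatic nitrogen, gives an 8.4-fold higher number from compound 1 to compound 3 (0.92 log units; beyond the scatter). Both steps lie beyond the scatter, whereas propyl and cyclobutyl remain close, with a 1.9-fold higher number from compound 1 to compound 2 (0.28 log units; within the scatter), so among these three compounds the ethyl group alone stands apart, and the earlier pair had not revealed that a shorter branch could raise the number. Nothing available explains this loss of affinity.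

The compounds shown leave open whether methyl at this carbon would raise the number further, or whether the rise stops at ethyl. They also leave open whether a longer chain such as butyl, or a smaller ring such as cyclopropyl, would keep the number close to those of compound 1 and compound 2.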